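A Thiourea Swap on the Ring Nitrogen of Compound 3

This account rests on a few compounds, and the source may have more. Where it says the series, first, only, none or still open, it means among the compounds named here.

In an assay for binding affinity to Apoptosis regulator Bcl-2 (Homo sapiens), read by fluorescence polarization, with stated times of 30 min and 20 min, tested at 100 uM (on this read-out lower numbers stand for less inhibition and higher numbers for more inhibition at the one concentration tested (going by the name of the read-out)), compound 3 `COc1ccc(Oc2ccccc2-c2ccsc2S(=O)(=O)N2CCN(C(=O)Nc3cccc([N+](=O)[O-])c3)CC2)cc1OC` gives 18%, level with compound 1 `COc1ccc(Oc2ccc([N+](=O)[O-])cc2-c2ccsc2S(=O)(=O)N2CCN(C(=S)Nc3ccc(Cl)cc3)CC2)cc1OC` at 18%, and together these are the lowest of the three numbers, while compound 2 `O=C(Nc1cccc([N+](=O)[O-])c1)N1CCN(S(=O)(=O)c2sccc2-c2ccccc2Oc2ccc(O)c(O)c2)CC1` gives 30%. Among the compounds with values here, the one measured step, a number 12 percentage points lower from compound 2 to compound 3 (beyond the scatter), concerns the dimethoxyphenyl oxygen group and not the change at hand. Compound 4 `COc1ccc(Oc2ccccc2-c2ccsc2S(=O)(=O)N2CCN(C(=S)Nc3ccc(Cl)cc3)CC2)cc1OC` differs from compound 3 as follows: a group of 10 heavy atoms (7 carbon, 1 nitrogen, 1 sulfur, 1 chlorine; one six-membered aromatic ring of carbon only) in place of a group of 12 heavy atoms (7 carbon, 2 nitrogen, 3 oxygen; one six-membered aromatic ring of carbon only), on an amine nitrogen in a ring. Within the data shown here, no measured step covers this swap, but compound 1 already carries the entering group and sits where compound 3 does. Compound 4 is therefore expected to show no step beyond the scatter, no change at the digits printed from compound 3 to compound 4 (within the scatter), with an estimated 18% and a range from 5% to 32%.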

Compound 4, a percentage reported as inhibition, at one concentration (the size of the read-out at that concentration, not a potency): 18%
Compound 4: middle estimate and measured number agree at the digits printed; the measured number falls inside the stated range.
By their numbers in this assay, from the lowest: compounds 1, 3 and 4 (each within the scatter of the next); then compound 2.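

In this assay, replacing the (3-nitrophenyl)carbamoyl group on the ring amine nitrogen gives no change at the digits printed from compound 3 to compound 4 (within the scatter), so this larger swap leaves the reading within the scatter at this low level. Hydrogen in place of nitro on an aromatic carbon of the core gives no change at the digits printed from compound 1 to compound 4 (within the scatter), so this pair separates the two compounds at no point of the read-out. No independent measurement helps to interpret these matches. Still open, on these data alone, is whether a carboxylic acid in place of the chlorine would shift the reading. Also open, as far as these compounds go, is whether the 3,4-dihydroxyphenyl group of compound 2 would raise the reading when paired with the group now on the ring nitrogen.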